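The source may hold more compounds than are shown below. What is called first, only, known or untested is meant among the compounds shown, and "the series" means these compounds.

Measured so far in a functional assay (Pituitary gland cell) with Rattus norvegicus as the target; on this read-out lower numbers stand for an effect already at smaller amounts and higher numbers for an effect only at larger amounts of compound:
compound 1 `CC(C)(N)CC(=O)N[C@@H]1CCc2ccccc2N(Cc2ccc(-c3ccccc3C(=O)O)cc2)C1=O` — 2500 nM
compound 2 `Cc1noc(-c2ccccc2-c2ccc(CN3C(=O)[C@H](NC(=O)CC(C)(C)N)CCc4ccccc43)cc2)n1` — 1050 nM
compound 3 `CC(C)(N)CC(=O)N[C@@H]1CCc2ccccc2N(Cc2ccc(-c3ccccc3-c3nc[nH]n3)cc2)C1=O` — 90 nM

Compound 1 stands at the highest number of the three. Its nearest neighbour is compound 2: a 2.4-fold lower number from compound 1 to compound 2 (0.38 log units; beyond the scatter). The furthest is compound 3: a 28-fold lower number from compound 1 to compound 3 (1.44 log units; beyond the scatter). Between the two five-membered rings, a 12-fold lower number from compound 2 to compound 3 (1.07 log units; beyond the scatter), so the ring with more ring nitrogens and a free ring hydrogen gave the clearly lower number.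

Compound 4 `CC(C)(N)CC(=O)N[C@@H]1CCc2ccccc2N(Cc2ccc(-c3cccnc3-c3nn[nH]n3)cc2)C1=O` is unmeasured. Its change from compound 1 is: 2-(2H-tetrazol-5-yl)pyridin-3-yl in place of 2-carboxyphenyl on an aromatic carbon. Two of the measured steps bear on this, both replacing carboxy on the aromatic carbon by a five-membered aromatic ring, and both lowered the number, one modestly and one strongly. Compound 4 carries a five-membered ring with still more hetero atoms and a ring hydrogen, which points toward the behaviour of compound 3 rather than compound 2. Among the measured compounds shown here, the six-membered ring also changes from carbon only to one with a ring nitrogen; no measured pair covers that part, so it adds uncertainty without a direction from the data.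

A large downward step is therefore expected, a 10-fold lower number from compound 1 to compound 4 (1.00 log units; beyond the scatter), somewhat short of the step to compound 3. The estimate for compound 4 in this assay is 250 nM, with a range from 60 nM to 1000 nM.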

Compound 4, half-maximal effective concentration: 2350 nM
For compound 4 the middle estimate is 9.4-fold (0.97 log units) below the measured one; measured number outside the range, above it.
By their numbers in this assay, from the lowest: compound 3; then compound 2; then compounds 4 and 1 (each within the scatter of the next).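

In this assay, the replacement of 2-carboxyphenyl by 2-(2H-tetrazol-5-yl)pyridin-3-yl gives no readable change (a 1.1-fold lower number from compound 1 to compound 4 (0.03 log units; within the scatter)), so at this position, on an aromatic carbon para to a large group, an aromatic five-membered ring in place of the carboxy-bearing arrangement does not by itself bring a lower number. The new group also stands clearly on the high side of the two other rings (a 26-fold higher number from compound 3 to compound 4 (1.42 log units; beyond the scatter)) and (a 2.2-fold higher number from compound 2 to compound 4 (0.35 log units; beyond the scatter)), and this breaks the earlier reading: compound 4 has more ring hetero atoms than compound 3 and a ring hydrogen like it, yet compound 2, with no ring hydrogen, has the lower number. No measurement in hand accounts for these differences.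

Compound 4 alters the five-membered ring and the six-membered ring together, so the share of each in the result remains unresolved. A 2-(2H-tetrazol-5-yl)phenyl group, or a pyridin-3-yl ring carrying the 1H-1,2,4-triazol-3-yl group, would separate the two contributions.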